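The source may hold more compounds than are shown below. What is called first, only, known or untested is meant among the compounds shown, and "the series" means these compounds.

Measured so far in a functional assay on ECa-109 cells (Homo sapiens) for cytotoxicity, read by MTT assay, with a stated time of 72 h; a higher number here means a weaker inhibitor, a lower number a stronger inhibitor:
Compound 1 `CN(C)c1ccc(C=C2C(=O)N(c3ccc(Cl)cc3)N(c3ccc(Cl)cc3)C2=O)cc1`: for compound 1 the assay reports only a limit, > 128000 nM.
Compound 2 `O=C1C(=Cc2ccc(Cl)cc2)C(=O)N(c2ccc(Cl)cc2)N1c1ccc(Cl)cc1`: compound 2 gives 17300 nM.
Compound 3 `COc1cccc(C=C2C(=O)N(c3ccc(Cl)cc3)N(c3ccc(Cl)cc3)C2=O)c1`: compound 3 gives 29000 nM.

Compound 2 holds the lowest of the two numbers in this assay, but its nearest neighbour lies close: a 1.7-fold higher number from compound 2 to compound 3 (0.22 log units; within the scatter), within the scatter. The value of compound 1 is the one that sits at the limit of > 128000 nM in this assay, at which 1 of the 3 values shown sits, so it is a limit and not a number.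

Compound 4 `COc1ccccc1C=C1C(=O)N(c2ccc(Cl)cc2)N(c2ccc(Cl)cc2)C1=O` has not yet been measured. It differs from compound 2 in a single place: 2-methoxyphenyl in place of 4-chlorophenyl on a double-bonded chain carbon bound to a double-bonded ring carbon. The measured step that bears most directly on this is a 1.7-fold higher number from compound 2 to compound 3 (0.22 log units; within the scatter), where a 3-methoxyphenyl took the place of the same 4-chlorophenyl and the number moved only within the scatter. The other two steps, an at least 7.3-fold lower number from compound 1 to compound 2 (0.86 log units; beyond the scatter) and an at least 4.4-fold lower number from compound 1 to compound 3 (0.64 log units; beyond the scatter), concern a different replacement and begin from a limit, so they speak only to compound 1 being the weak member of the set. On this basis compound 4 is expected to show no step beyond the scatter in this assay, an estimate of 25000 nM with a range from 10000 nM to 70000 nM. The expected step is a 1.4-fold higher number from compound 2 to compound 4 (0.16 log units; within the scatter).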

Compound 4, half-maximal inhibitory concentration: 30400 nM
Compound 4: the middle estimate sits 1.2-fold (0.08 log units) below what was measured; the range from low to high includes it.
By their numbers in this assay, from the lowest: compounds 2, 3 and 4 (each within the scatter of the next). At a limit, above all of these: compound 1.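

Setting a 2-methoxyphenyl on the double-bonded chain carbon bound to a double-bonded ring carbon gives a 1.8-fold higher number from compound 2 to compound 4 (0.24 log units; within the scatter) in this assay, so a second methoxyphenyl, like the 3-methoxyphenyl of compound 3, shows no step beyond the scatter when it replaces the 4-chlorophenyl. The new comparison is between the two methoxyphenyl groups themselves: 2-methoxyphenyl in place of 3-methoxyphenyl gives a 1.0-fold higher number from compound 3 to compound 4 (0.02 log units; within the scatter), so this assay does not separate these two placements of the methoxy group. Compound 4 also stands apart from the dimethylamino compound, with an at least 4.2-fold lower number from compound 1 to compound 4 (0.62 log units; beyond the scatter), but that step starts from a limit and not from a number: the limit of > 128000 nM in this assay, at which 1 of the 4 values shown sits.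

Within the data shown here, the 4-(dimethylamino)phenyl of compound 1 remains the only group here that gives a step beyond the scatter, and a single compound cannot show whether other groups on this ring would behave the same way. Going by these compounds, it remains open how a phenyl carrying a primary amine or a carboxylic acid would compare, and whether a 4-methoxyphenyl would stay within the scatter of compound 3 and compound 4.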